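The source may report more compounds than this note shows. Statements on the series, on what has been measured and on what is new or still open speak of the compounds shown alone.

Measured so far in an ADME assay on Hippocampus (Mus musculus), read by LDH release; a lower number here means that less compound is tolerated, a higher number that more compound is tolerated:
- compound 1 `CCCNc1c(O)cc2oc(-c3ccccc3)cc(=O)c2c1O`: 176 uM
- compound 2 `CC(C)CCNc1c(O)cc(O)c2c(=O)cc(-c3ccccc3)oc12`: 16 uM
- compound 3 `CC(C)CNc1c(O)cc(O)c2c(=O)cc(-c3ccccc3)oc12`: 12 uM

Compound 3 sits at the low end of these three numbers. It lies within the scatter of compound 2, while compound 1 stands higher, well beyond the scatter.

The next compound is compound 4 `CCCNc1c(O)cc(O)c2c(=O)cc(-c3ccccc3)oc12`, not yet measured in this assay. It differs from compound 3 as follows: hydrogen in place of methyl on a saturated chain carbon bound to two saturated chain carbons. In words, hydrogen takes the place of methyl on a saturated chain carbon bound to two saturated chain carbons, which turns isobutylamino into propylamino.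

For the measured compounds named here, one measured step bears on this change, since it also alters the same chain: a 1.3-fold lower number from compound 2 to compound 3 (0.12 log units; within the scatter). That step stays within the scatter. Going by the values given here, no measured step connects compound 1 to any other compound, so its value gives no step size to carry over. On this single step, no change beyond the scatter is expected, and no direction can be assigned. This is thin evidence, so the range is kept wide.

The expected step is a 1.3-fold higher number from compound 3 to compound 4 (0.10 log units; within the scatter).

For compound 4 the estimated value is 15 uM, with an expected range of 6 uM to 40 uM.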

Compound 4, half-maximal toxic concentration: 28 uM
The estimate for compound 4 lay 1.9-fold (0.27 log units) below the measured number, and the stated range covers the measured number.
By their numbers in this assay, from the lowest: compounds 3, 2 and 4 (each within the scatter of the next, the first and the last beyond it); then compound 1.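

In this assay, hydrogen in place of methyl on a saturated chain carbon bound to two saturated chain carbons, which turns isobutylamino into propylamino, gives a 2.3-fold higher number from compound 3 to compound 4 (0.37 log units; beyond the scatter). For the compounds shown here, this modest change is the first one on this chain to pass the scatter, so the chain is not wholly silent in this assay, as the earlier step within the scatter might have suggested. The other new step, a 1.8-fold higher number from compound 2 to compound 4 (0.24 log units; within the scatter), stays within the scatter, so among the three chains on this core only compound 3 and compound 4 are separated, and no ordering by chain can be claimed; nothing available explains the separation that is seen.

Still open, going by these compounds, is whether the trend toward more compound being tolerated continues with a shorter ethylamino or a plain amino group on the same core, or whether it reverses with a longer chain such as hexylamino. Also open is how a chain ending in a carboxylic acid or a terminal amine would read here, since every chain shown is a plain saturated one.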